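This account rests on a few compounds, and the source may have more. Where it says the series, first, only, none or still open, it means among the compounds named here.

In an ADME assay on Jurkat cells (Homo sapiens) for cytotoxicity (on this read-out higher numbers stand for weaker inhibition and lower numbers for stronger inhibition), compound 1 `Cc1nc(-c2ccccc2)sc1C(=O)N[C@H](/C=C/S(=O)(=O)c1ccccc1)CCc1ccccc1` gives > 100000 nM, which is a limit and not a number. Compound 2 `Cc1nc(-c2cnccn2)sc1C(=O)N[C@H](/C=C/S(=O)(=O)c1ccccc1)CCc1ccccc1` likewise gives only a limit, > 100000 nM. As far as these compounds go, compound 3 `O=C(N[C@H](/C=C/S(=O)(=O)c1ccccc1)CCc1ccccc1)c1cc(-c2ccccc2)no1` also stands at a limit, > 100000 nM, so its exact place on the scale is unknown. The move to compound 4 `O=C(N[C@H](/C=C/S(=O)(=O)c1ccccc1)CCc1ccccc1)c1cc(-c2ccccn2)no1` puts pyridin-2-yl in place of phenyl on an aromatic carbon. Among the compounds with values here, the one measured step that bears on this is a step that the two limits leave unreadable from compound 1 to compound 2, where pyrazin-2-yl replaces phenyl. That step offers no size, and the expectation therefore rests on the limit of > 100000 nM in this assay, at which 3 of the 3 values shown sit: no step beyond the scatter is expected in this assay. The expected change is a number no higher from compound 3 to compound 4 (the limit leaves the size open). For compound 4 the estimate is 100000 nM, with an expected range from 50000 nM to 200000 nM.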

Compound 4, half-maximal inhibitory concentration: > 100000 nM
Compound 4 gave a limit, no number; the forecaster's own chance of this, stated with the estimate: 90%; the middle value sits exactly at the limit.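

Compound 3 and compound 4 both give only a limit in this assay, so no step can be read between them: the limit of > 100000 nM in this assay, at which 4 of the 4 values shown sit.

The compounds shown leave open whether swapping phenyl for pyridin-2-yl changes this read-out at all.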